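Oxytocin receptor series: replacing the five-membered aryl on the chain carbon

A few compounds are considered here, and "the series" means these few. Any claim that something is new, unique, unknown or untested is made for them only; others in the source may bear on it.

Working notes on two measured compounds and one not yet measured. Compound 1 `CC(C)C[C@@H]1C(=O)N[C@H](C2Cc3ccccc3C2)C(=O)N1[C@@H](C(=O)NC(C)C)c1ccco1` gives 6.31 nM in an assay on isolated protein for binding affinity to Oxytocin receptor (Homo sapiens); on this read-out lower numbers stand for stronger inhibition and higher numbers for weaker inhibition. For the measured compounds named here, compound 2 `CC(C)C[C@@H]1C(=O)N[C@H](C2Cc3ccccc3C2)C(=O)N1[C@@H](C(=O)NC(C)C)c1ccc(Br)s1` gives 2 nM in this assay, the lowest of the two numbers so far; its only neighbour is compound 1, and the step of a 3.2-fold lower number from compound 1 to compound 2 (0.50 log units; beyond the scatter) is beyond the scatter. Compound 3 `CC(C)C[C@@H]1C(=O)N[C@H](C2Cc3ccccc3C2)C(=O)N1[C@@H](C(=O)NC(C)C)c1coc(C(F)(F)F)n1` is not yet measured. It differs from compound 2 by a group of 9 heavy atoms (4 carbon, 1 nitrogen, 1 oxygen, 3 fluorine; one five-membered aromatic ring with 2 hetero atoms) in place of a group of 6 heavy atoms (4 carbon, 1 sulfur, 1 bromine; one five-membered aromatic ring with 1 hetero atom), on a saturated chain carbon bound to an amide-type nitrogen in a ring and a carbonyl carbon. Going by the values given here, the single measured step that bears on this position, a 3.2-fold lower number from compound 1 to compound 2 (0.50 log units; beyond the scatter), shows that exchanging one five-membered aromatic ring for another at this chain carbon moves the number modestly, and it gives no guide to a ring with two hetero atoms carrying trifluoromethyl. Two measured compounds do not establish a pattern. The estimate for compound 3 is therefore placed between the two measured values and slightly toward compound 1, a step of a 2.5-fold higher number from compound 2 to compound 3 (0.40 log units; beyond the scatter) that is expected to be a weakening. Compound 3 is expected to give about 5 nM in this assay, with a range from 1.5 nM to 20 nM.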

Compound 3, inhibition constant: 0.159 nM
For compound 3 the middle estimate is 31-fold (1.50 log units) above the measured one; measured number below the stated range.
By their numbers in this assay, from the lowest: compound 3; then compound 2; then compound 1.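

In this assay, the aromatic group on this saturated chain carbon can move the number much further than the exchange of furan-2-yl for 5-bromothiophen-2-yl indicated. The five-membered aromatic ring with two hetero atoms and a trifluoromethyl group gives a 13-fold lower number from compound 2 to compound 3 (1.10 log units; beyond the scatter) and a 40-fold lower number from compound 1 to compound 3 (1.60 log units; beyond the scatter); both steps are large and beyond the scatter, so compound 3 has the lowest number of the three and the position is far from exhausted by the earlier modest step. No available evidence bears on the origin of this gain.

The step to compound 3 changes the ring and its substituent together, so the shares of the two added hetero-atom features and of the trifluoromethyl group cannot be separated from these three compounds alone. On these data alone, it remains open whether the same ring would hold the low number with a methyl group, a nitrile or a bromine atom in place of trifluoromethyl, and whether a six-membered ring such as pyridine would fit this chain carbon equally well.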